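Trading a Methoxyphenyl Arm for an Aminophenyl Arm

The source may report more compounds than this note shows. Statements on the series, on what has been measured and on what is new or still open speak of the compounds shown alone.

Of the compounds shown here, two built on a shared core have been measured so far. Compound 1 `COc1ccc(-c2cc(-c3ccccc3)n[nH]2)cc1` gives 11300 nM in a functional assay on AGS cells (Homo sapiens) for inhibition, read by MTT assay, with a stated time of 48 h; on this read-out higher numbers stand for weaker inhibition of growth and lower numbers for stronger inhibition of growth. Compound 2 `COc1cccc(-c2cc(-c3ccccc3-c3ccccc3)n[nH]2)c1` gives 7500 nM in this assay; this is the lowest of the two numbers, yet the value of compound 1 sits within the usual scatter of it, so the two compounds cannot be set apart on these numbers.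

Compound 3 `Nc1ccc(-c2cc(-c3ccccc3-c3ccccc3)n[nH]2)cc1` has not yet been measured. It differs from compound 2 in a single place: 4-aminophenyl in place of 3-methoxyphenyl on an aromatic carbon. Among the compounds with values here, no pair of measured compounds differs in just this way, as compound 1 and compound 2 differ in two places at once, so nothing measured here shows what this change does. The step of a 1.2-fold lower number from compound 2 to compound 3 (0.06 log units; within the scatter) is therefore expected to stay within the scatter, with no clear direction. Compound 3 is estimated at 6500 nM in this assay, in a range from 2000 nM to 20000 nM.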

Compound 3, concentration for 50% growth inhibition: 8400 nM
The estimate for compound 3 lay 1.3-fold (0.11 log units) below the measured number; low and high end bracket the measured number.
By their numbers in this assay, from the lowest: compounds 2, 3 and 1 (each within the scatter of the next).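

In this assay, putting 4-aminophenyl in place of 3-methoxyphenyl on this aromatic carbon gives a 1.1-fold higher number from compound 2 to compound 3 (0.05 log units; within the scatter), so the two compounds cannot be set apart. This is the first pair shown that differs in just one place, and it shows that an arm with a hydrogen-bond donor and an arm without one can sit at this position with no difference that stands out from the scatter. Nothing measured alongside these numbers speaks to why the two arms read alike.

The step changes both the group on the arm and where that group sits, and the compounds shown do not separate the two. Also open, from the compounds shown here alone, is whether a different group on this arm, such as a carboxylic acid or a longer chain, would give a difference beyond the scatter.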